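This account rests on a few compounds, and the source may have more. Where it says the series, first, only, none or still open, it means among the compounds named here.

In an ADME assay on HepG2 cells (Homo sapiens) for cytotoxicity, read by luminescence, CellTiter-Glo and ATP content, with a stated time of 72 h (a higher number here means that more compound is needed for the effect, a lower number that less compound is needed), three compounds have been measured:

Compound 1 `COc1ccccc1Oc1ccc2c(NCCCNCc3ccco3)ccnc2c1`: 6500 nM
Compound 2 `COc1cccc(CNCCCNc2ccnc3cc(-c4ccc(C(F)(F)F)cc4)ccc23)c1O`: 2210 nM
Compound 3 `FC(F)(F)c1ccc(-c2ccc3c(NCCCNCc4ccco4)ccnc3c2)cc1`: 3470 nM

Compound 2 holds the lowest of the three numbers. Its nearest neighbour is compound 3, a 1.6-fold higher number from compound 2 to compound 3 (0.20 log units; within the scatter), a gap within the scatter; furthest is compound 1, whose value 6500 nM lies beyond the scatter from that of compound 2.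

Compound 4 `COc1cccc(CNCCCNc2ccnc3cc(Oc4cccc(N(C)C)c4)ccc23)c1O` is not yet measured. It differs from compound 2 in one place: 3-(dimethylamino)phenoxy in place of 4-(trifluoromethyl)phenyl on an aromatic carbon. For the measured compounds named here, the one measured step at the same place is the exchange of an aryloxy group for the trifluoromethyl-bearing phenyl, a 1.9-fold lower number from compound 1 to compound 3 (0.27 log units; within the scatter), which stayed within the scatter. On that basis the step to compound 4 in this assay is expected to be small, if anything toward a higher number, a 1.5-fold higher number from compound 2 to compound 4 (0.17 log units; within the scatter). Compound 4 is therefore estimated at 3300 nM, with a range from 1100 nM to 10000 nM.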

Compound 4, half-maximal effective concentration: 7300 nM
The estimate for compound 4 lay 2.2-fold (0.34 log units) below the measured number, within the range that was stated.
By their numbers in this assay, from the lowest: compounds 2, 3, 1 and 4 (each within the scatter of the next, the first and the last beyond it).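

In this assay, the exchange at this aromatic carbon gives a 3.3-fold higher number from compound 2 to compound 4 (0.52 log units; beyond the scatter), so this position can carry a change that lies beyond the scatter. The earlier step at the same place, a 1.9-fold lower number from compound 1 to compound 3 (0.27 log units; within the scatter), stayed within it and was made with a furan-2-yl side chain and a different aryloxy group. No evidence is available to explain the new step.

The exchange alters the ring's link and its substituent together, so the compounds leave open which of the two matters. An unsubstituted phenoxy or a 3-(dimethylamino)phenyl at this carbon would separate them.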